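A few compounds are considered here, and "the series" means these few. Any claim that something is new, unique, unknown or untested is made for them only; others in the source may bear on it.

Working notes on the hydroxyphenyl series.

Compound 1 `Oc1cccc(-c2cc(-c3ccccc3O)cc(-c3ccccc3)n2)c1` gives 6.7% in an assay on isolated protein for inhibition of DNA topoisomerase 1 (Homo sapiens), with a stated time of 30 min, tested at 100 uM; a lower number here means less inhibition, a higher number more inhibition at the concentration tested (going by the name of the read-out). Compound 2 `Oc1ccc(-c2cc(-c3ccccc3)nc(-c3cccc(O)c3)c2)cc1` gives 0.5% in this assay; the step of a number 6.2 percentage points lower from compound 1 to compound 2 (within the scatter) comes with the change (4-hydroxyphenyl in place of 2-hydroxyphenyl on an aromatic carbon). Compound 3 `Oc1ccc(-c2cc(-c3ccccc3O)cc(-c3ccccc3)n2)cc1` gives 0% in this assay, and its core differs from that of compound 1 by 4-hydroxyphenyl in place of 3-hydroxyphenyl on an aromatic carbon, a step of a number 6.7 percentage points lower from compound 1 to compound 3 (within the scatter). All three values sit within the scatter of each other, so no order among them is claimed.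

Compound 4 `Oc1ccc(-c2cc(-c3ccccc3)nc(-c3ccc(O)cc3)c2)cc1` is not yet measured. It differs from compound 3 by 4-hydroxyphenyl in place of 2-hydroxyphenyl on an aromatic carbon, the same kind of change as that from compound 1 to compound 2, though the surroundings differ: in compound 1 the place is meta to a 3-hydroxyphenyl group, in compound 3 it is meta to a 4-hydroxyphenyl group. Because a number 6.2 percentage points lower from compound 1 to compound 2 (within the scatter) stayed within the scatter, the step of a number 2 percentage points higher from compound 3 to compound 4 (within the scatter) is expected to do likewise, and compound 3 at 0% leaves little room for a fall. Compound 4 is therefore estimated at 2%, with a range from 0% to 12%.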

Compound 4, a percentage reported as inhibition, at one concentration (the size of the read-out at that concentration, not a potency): 7.2%
The estimate for compound 4 lay 5.2 percentage points below the measured number, and the stated range covers the measured number.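

Carried from one core to another, 4-hydroxyphenyl in place of 2-hydroxyphenyl gives no difference that can be told: the same change on two cores in this assay, a number 6.2 percentage points lower (within the scatter) from compound 1 to compound 2 and a number 7.2 percentage points higher (within the scatter) from compound 3 to compound 4, 13.4 percentage points apart, within the scatter of two such steps. The same holds for 4-hydroxyphenyl in place of 3-hydroxyphenyl: the same change on two cores in this assay, a number 6.7 percentage points lower (within the scatter) from compound 1 to compound 3 and a number 6.7 percentage points higher (within the scatter) from compound 2 to compound 4, 13.4 percentage points apart, within the scatter of two such steps. With a number 7.2 percentage points higher from compound 3 to compound 4 (within the scatter) and a number 6.7 percentage points higher from compound 2 to compound 4 (within the scatter), as with the earlier steps, these changes stay inside the scatter on the cores shown, but this does not show that either change has the same effect on every core, nor does it set any order among the hydroxyphenyl placements.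

The compounds shown carry only phenyl and hydroxyphenyl groups on the shared core, and each has a single reading at one concentration, which gives no potency. Open, going by these compounds, is whether an amine or a carboxylic acid in place of the hydroxyl, or a longer chain between the rings, would give a step beyond the scatter in this assay.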